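The compounds below may be only part of what the source reports. "The series", "measured", "known", "first", "only" and "open" are said of these compounds alone.

Measured in a functional assay on SH-SY5Y cells (Homo sapiens) for antiproliferative activity, read by MTT assay, with a stated time of 48 h; on this read-out lower numbers stand for stronger inhibition of growth and higher numbers for weaker inhibition of growth:
- Compound 1 `COc1ccc(N(C)c2ncnc3[nH]cnc23)cc1`: > 100000 nM, a limit
- Compound 2 `COc1ccc(N(C)c2nc(Cl)nc3[nH]cnc23)cc1`: > 100000 nM, a limit
- Compound 3 `COc1ccc(N(C)c2ncnc3c2ncn3Cc2ccc(OC)c(OC)c2)cc1`: 430 nM

A value with a sign like this is a limit of the assay and not a number. Compound 2 therefore has no exact position and stands at the limit of > 100000 nM in this assay, at which 2 of the 3 values shown sit. For the measured compounds named here, the one measured step is a step that the two limits leave unreadable from compound 1 to compound 2, so it offers no size to build on.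

Compound 4 `COc1ccc(Cn2cnc3c(N(C)c4ccc(OC)cc4)nc(Cl)nc32)cc1` takes compound 2 and puts 4-methoxybenzyl in place of hydrogen on an aromatic nitrogen.

Going by the values given here, the only guide is compound 3, which also carries a methoxy-bearing benzyl group on that aromatic nitrogen and gives a real number, 430 nM. On the strength of that value, a large move towards stronger inhibition of growth seems likely in this assay. The expected size is an at least 330-fold lower number from compound 2 to compound 4 (2.52 log units; beyond the scatter), and it is uncertain since compound 2 has only a limit. For compound 4 the estimated value is 300 nM, with an expected range from 40 nM to 3000 nM.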

Compound 4, concentration for 50% growth inhibition: 31000 nM
Compound 4: the middle estimate sits 100-fold (2.01 log units) below what was measured, outside the stated range (above it).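

In this assay, 4-methoxybenzyl in place of hydrogen on this aromatic nitrogen brings a compound with the chloro group into a measurable range, with an at least 3.2-fold lower number from compound 2 to compound 4 (0.50 log units; beyond the scatter). Compound 3 differs from compound 4 in more than one place, so it cannot show which change accounts for the difference in their values, and a methoxy-bearing benzyl group on this nitrogen cannot be given a single effect. The step can be read only as a minimum, and its true size stays unknown because compound 2 has no exact value: the limit of > 100000 nM in this assay, at which 2 of the 4 values shown sit.

The compounds shown leave open how a plain benzyl, a methyl, or a chain ending in an amine or a carboxylic acid would behave on this nitrogen. They also leave open what the chloro group does once this nitrogen carries a benzyl group.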